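A few compounds are considered here, and "the series" means these few. Any claim that something is new, unique, unknown or untested is made for them only; others in the source may bear on it.

Measured so far:
Compound 1, `O=C(O)c1ccc2nc(CN3CCC[C@H](O[C@H](CO)c4cc(Cl)cc(Cl)c4)[C@@H]3c3ccccc3)[nH]c2c1`, gives 380 nM in an assay on isolated protein for activation of cGMP-dependent protein kinase 1 (Homo sapiens), read by ADP-Glo, with stated times of 30 min and 2 h, in the presence of a further agent that is not named here; a higher number here means that more compound is needed for the effect, a lower number that less compound is needed.
Compound 2, `Nc1cc(C(=O)O)ccc1CN1CCC[C@H](O[C@H](CO)c2cc(Cl)cc(Cl)c2)[C@@H]1c1ccccc1`, gives 290 nM in this assay.
Compound 3, `Cc1nc(C(=O)O)ccc1CN1CCC[C@H](O[C@H](CO)c2cc(Cl)cc(Cl)c2)[C@@H]1c1ccccc1`, gives 370 nM in this assay.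

Among these three numbers compound 3 stands second highest; its nearest neighbour is compound 1, with a 1.0-fold lower number from compound 1 to compound 3 (0.01 log units; within the scatter), and its furthest is compound 2, with a 1.3-fold higher number from compound 2 to compound 3 (0.11 log units; within the scatter). Among the measured compounds shown here, all three compounds share one core and differ only in the group carried on a saturated chain carbon bound to an amine nitrogen in a ring, and none of the measured steps, a 1.3-fold lower number from compound 1 to compound 2 (0.12 log units; within the scatter) included, moves the number beyond the scatter.

Compound 4, `OC[C@@H](O[C@H]1CCCN(Cc2nc3ccccc3[nH]2)[C@H]1c1ccccc1)c1cc(Cl)cc(Cl)c1`, has not yet been measured in this assay. Compared with compound 3 the change is a group of 9 heavy atoms (7 carbon, 2 nitrogen; one five-membered aromatic ring with 2 hetero atoms, one six-membered aromatic ring of carbon only) in place of a group of 10 heavy atoms (7 carbon, 1 nitrogen, 2 oxygen; one six-membered aromatic ring with 1 hetero atom), on a saturated chain carbon bound to an amine nitrogen in a ring. The entering group is also part of the larger group carried by compound 1, so the step of a 1.0-fold lower number from compound 1 to compound 3 (0.01 log units; within the scatter) bears on this change; yet the group carried by compound 1 holds two oxygens, and in compound 4 the two oxygens of the leaving group are not replaced. For the measured compounds named here, no measured pair shows what that loss does. Since every step seen so far lies within the scatter, a small step, if anything a modest rise in the number, is expected. For compound 4 a value of 600 nM is estimated, within 200 nM to 2000 nM, which would mean an expected step of a 1.6-fold higher number from compound 3 to compound 4 (0.21 log units; within the scatter).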

Compound 4, half-maximal effective concentration: 4700 nM
For compound 4 the middle estimate is 7.8-fold (0.89 log units) below the measured one; measured number above the stated range.
By their numbers in this assay, from the lowest: compounds 2, 3 and 1 (each within the scatter of the next); then compound 4.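

Among the compounds shown here, the cleanest reading comes from the pair that differs only by hydrogen in place of carboxy on an aromatic carbon, which gives a 12-fold higher number from compound 1 to compound 4 (1.09 log units; beyond the scatter) in this assay, the first step in this set to lie beyond the scatter. For the compounds shown here, the exchanges of 1H-benzimidazol-2-yl for the larger groups point the same way, with a 16-fold higher number from compound 2 to compound 4 (1.21 log units; beyond the scatter) and a 13-fold higher number from compound 3 to compound 4 (1.10 log units; beyond the scatter), so the place on the saturated chain carbon accepts quite different groups carrying a carboxy group, while the one group here without carboxy stands apart, and none of the four compounds goes against this pattern. Nothing measured here explains why the number rises when the carboxy group is absent.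

The compounds shown leave open whether a carboxylic acid is strictly needed, which a primary amide or a tetrazole on the same aromatic carbon could test. They also leave open whether the carboxy group matters as much on the other groups, as a phenyl group carrying only the 2-amino substituent, compared with compound 2, would show.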